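Swapping 4-fluorobenzyl for 2-chlorobenzyl

The source may report more compounds than this note shows. Statements on the series, on what has been measured and on what is new or still open speak of the compounds shown alone.

- compound 1 `COc1ccc(/C=C2\CN(Cc3cn(Cc4cccc(Cl)c4)nn3)C/C(=C\c3ccc(OC)cc3)C2=O)cc1`: 32500 nM
- compound 2 `O=C1/C(=C/c2ccccc2F)CN(C(=S)SCc2cn(Cc3ccccc3Cl)nn2)C/C1=C\c1ccccc1F`: > 80000 nM (a limit, not a number)
- compound 3 `COc1ccc(/C=C2\CN(Cc3cn(Cc4ccc(F)cc4)nn3)C/C(=C\c3ccc(OC)cc3)C2=O)cc1`: 67500 nM

In a functional assay on PC-3 cells (Homo sapiens) for cytotoxicity, read by MTT assay, with a stated time of 24 h (a lower number here means a stronger inhibitor, a higher number a weaker inhibitor), compound 3 has the higher of the two true numbers (67500 nM) and so is the weaker of that pair. Compound 4 `COc1ccc(/C=C2\CN(Cc3cn(Cc4ccccc4Cl)nn3)C/C(=C\c3ccc(OC)cc3)C2=O)cc1` keeps the shared core but carries 2-chlorophenyl in place of 4-fluorophenyl on a saturated chain carbon bound to an aromatic nitrogen. Among the compounds with values here, only one measured step bears on this change: the move to 4-fluorophenyl from 3-chlorophenyl gave a 2.1-fold higher number from compound 1 to compound 3 (0.32 log units; beyond the scatter), a modest rise. Compound 4 has its chlorine elsewhere on the ring, so a modest fall in the number is expected, though on thin evidence. The estimated change is a 1.7-fold lower number from compound 3 to compound 4 (0.23 log units; within the scatter). For compound 4 the expected value is 40000 nM, within an estimated range from 18000 nM to 80000 nM.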

Compound 4, half-maximal inhibitory concentration: 36300 nM
The estimate for compound 4 lay 1.1-fold (0.04 log units) above the measured number; low and high end bracket the measured number.
By their numbers in this assay, from the lowest: compounds 1, 4 and 3 (each within the scatter of the next, the first and the last beyond it). At a limit, above all of these: compound 2.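

In this assay, 2-chlorophenyl in place of 3-chlorophenyl gives a 1.1-fold higher number from compound 1 to compound 4 (0.05 log units; within the scatter), so these two chlorine placements cannot be told apart here. 2-chlorophenyl in place of 4-fluorophenyl gives a 1.9-fold lower number from compound 3 to compound 4 (0.27 log units; within the scatter), which places compound 4 within the scatter of both compound 1 and compound 3, even though those two lie beyond the scatter of each other. No measurement given here accounts for these numbers.

As far as these compounds go, what remains open is how this assay would respond to an amine or a carboxylic acid on the phenyl ring, or to a longer chain in place of the single saturated carbon.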